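Pyrazole carboxylic acid regioisomers in the benzyloxy-bromobenzyl series

This account rests on a few compounds, and the source may have more. Where it says the series, first, only, none or still open, it means among the compounds named here.

Compound 1 `O=C(O)c1ccn(Cc2cc(Br)ccc2OCc2ccccc2)n1` gives 55 nM in a functional assay on CHO-K1 cells for antagonist activity at prostaglandin E2 receptor EP1 subtype (Homo sapiens), read by FLIPR (a higher number here means a weaker inhibitor, a lower number a stronger inhibitor), the lower of the two numbers recorded. Compound 2 `Cc1cn(Cc2cc(Br)ccc2OCc2ccccc2)nc1C(=O)O` gives 1350 nM in this assay, and the step of a 25-fold higher number from compound 1 to compound 2 (1.39 log units; beyond the scatter) shows that even a small addition on the shared core is not well tolerated here. Compound 3 `O=C(O)c1ccnn1Cc1cc(Br)ccc1OCc1ccccc1` is not yet measured; it differs from compound 1 by 5-carboxy-1H-pyrazol-1-yl in place of 3-carboxy-1H-pyrazol-1-yl on a saturated chain carbon bound to an aromatic carbon. Going by the values given here, no measured step bears directly on this change: the only step recorded, from compound 1 to compound 2, is an addition of methyl, not a relocation of the acid. The large size of that step suggests that the core position of the acid is sensitive, so a weaker result than compound 1 is expected, with wide uncertainty. For compound 3 the expected step is a 5.5-fold higher number from compound 1 to compound 3 (0.74 log units; beyond the scatter), giving an estimate of 300 nM with a range from 50 nM to 3000 nM.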

Compound 3, inhibition constant: < 2000 nM
Compound 3 was reported as a limit (the forecaster's own chance of this, stated with the estimate: 10%); the middle value lies beyond the limit too.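

Going by these compounds alone, compound 3 is reported in this assay only as a limit, < 2000 nM, so no step from compound 1 to compound 3 can be read: the limit of < 2000 nM in this assay, at which 1 of the 3 values shown sits.

Still open, from the compounds shown here alone, is how 5-carboxy-1H-pyrazol-1-yl compares with 3-carboxy-1H-pyrazol-1-yl, in either size or direction.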